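The source may hold more compounds than are shown below. What is called first, only, known or untested is meant among the compounds shown, and "the series" means these compounds.

Three amides of the shared core have been measured. In a functional assay on A549 cells (Homo sapiens) for antiproliferative activity, read by MTT assay, with a stated time of 72 h (on this read-out lower numbers stand for stronger inhibition and higher numbers for weaker inhibition), compound 1 `O=C(Nc1ccc(F)cc1)C(Cl)Cl` gives 68400 nM, compound 2 `O=C(Nc1ccc(Cl)cc1)C(Cl)Cl` gives 20400 nM, and compound 3 `O=C(Nc1ccc(Br)cc1)C(Cl)Cl` gives 13700 nM, the lowest of the three numbers, although compound 3 is separated from compound 2 only by a step within the scatter. The measured steps were a 3.4-fold lower number from compound 1 to compound 2 (0.53 log units; beyond the scatter), a 5.0-fold lower number from compound 1 to compound 3 (0.70 log units; beyond the scatter) and a 1.5-fold lower number from compound 2 to compound 3 (0.17 log units; within the scatter). Compound 4 `O=C(Nc1ccc(SC(F)(F)F)cc1)C(Cl)Cl` differs from compound 3 by (trifluoromethyl)sulfanyl in place of bromo on an aromatic carbon. Among the compounds with values here, no measured step exchanges bromo for this group, so the expectation rests on the halogen series alone, where the exchanges from fluoro were beyond the scatter and the exchange from chloro to bromo was not. Compound 4 is therefore expected to give about 10000 nM in this assay, between 4000 nM and 30000 nM, an expected step of a 1.4-fold lower number from compound 3 to compound 4 (0.14 log units; within the scatter).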

Compound 4, half-maximal inhibitory concentration: 10600 nM
For compound 4 the middle estimate is 1.1-fold (0.03 log units) below the measured one; the range from low to high includes it.
By their numbers in this assay, from the lowest: compounds 4, 3 and 2 (each within the scatter of the next); then compound 1.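

In this assay the exchange of bromo for (trifluoromethyl)sulfanyl gives a 1.3-fold lower number from compound 3 to compound 4 (0.11 log units; within the scatter) and the exchange of chloro for it gives a 1.9-fold lower number from compound 2 to compound 4 (0.28 log units; within the scatter) so on this aromatic carbon a group that is not a halogen and holds more heavy atoms reads level with the two heavier halogens. Only the exchange of fluoro gives a step beyond the scatter, namely a 6.5-fold lower number from compound 1 to compound 4 (0.81 log units; beyond the scatter) and this matches the earlier exchanges from fluoro. Nothing available explains these steps. The compounds shown leave open how an amine, a carboxylic acid or a methoxy group would read at this place.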